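This account rests on a few compounds, and the source may have more. Where it says the series, first, only, none or still open, it means among the compounds named here.

Of the compounds shown here, three sharing one core have been measured in an assay on brain for displacement of a labelled ligand from D(3) dopamine receptor (Rattus norvegicus); on this read-out higher numbers stand for weaker inhibition and lower numbers for stronger inhibition. Compound 1 `CCCN(CC[C@H]1CC[C@H](NC(=O)/C=C/c2cccc(F)c2)CC1)[C@H]1CCc2nc(N)sc2C1` gives 9.9 nM; compound 2 `CCCN(CC[C@H]1CC[C@H](NS(=O)(=O)c2cccc3ccccc23)CC1)[C@H]1CCc2nc(N)sc2C1` gives 1.5 nM; and compound 3 `CCCN(CC[C@H]1CC[C@H](NS(=O)(=O)c2ccc(OC)cc2)CC1)[C@H]1CCc2nc(N)sc2C1` gives 0.78 nM, the lowest of the three numbers, though its gap to compound 2 stays within the scatter. The step of a 13-fold lower number from compound 1 to compound 3 (1.10 log units; beyond the scatter) is large, whereas a 1.9-fold lower number from compound 2 to compound 3 (0.28 log units; within the scatter) is small. Compound 4 `CCCN(CC[C@H]1CC[C@H](NS(=O)(=O)c2cccc(Cl)c2)CC1)[C@H]1CCc2nc(N)sc2C1` differs from compound 3 in one place: 3-chlorophenyl in place of 4-methoxyphenyl on a sulfonyl sulfur. Among the measured compounds shown here, only the step of a 1.9-fold lower number from compound 2 to compound 3 (0.28 log units; within the scatter) bears on this change: it too swaps one group on the sulfonyl sulfur for another, and it stayed within the scatter. A change within the scatter is therefore expected for a 1.5-fold higher number from compound 3 to compound 4 (0.19 log units; within the scatter). Compound 4 is estimated at 1.2 nM, within a range from 0.4 nM to 4 nM.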

Compound 4, inhibition constant: 1.1 nM
Compound 4: the middle estimate sits 1.1-fold (0.04 log units) above what was measured, within the range that was stated.
By their numbers in this assay, from the lowest: compounds 3, 4 and 2 (each within the scatter of the next); then compound 1.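

The 3-chlorophenyl group on the sulfonyl sulfur adds a third aromatic group that reads alike in this assay: a 1.4-fold higher number from compound 3 to compound 4 (0.15 log units; within the scatter) and a 1.4-fold lower number from compound 2 to compound 4 (0.13 log units; within the scatter) both remain within the scatter, even though chlorine replaces the oxygen-bearing methoxy group. The gap to the amide compound also holds with this new group, at a 9.0-fold lower number from compound 1 to compound 4 (0.95 log units; beyond the scatter), which is beyond the scatter. Nothing available explains these readings.

Going by these compounds, whether this tolerance extends beyond aromatic groups on the sulfonyl sulfur remains open. A methyl group or a longer alkyl chain there could test it.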